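The source may hold more compounds than are shown below. What is called first, only, known or untested is meant among the compounds shown, and "the series" means these compounds.

Compound 1 `COc1ccc2[nH]c(C)c(Cc3ccccc3)c(=O)c2c1` and compound 2 `COc1ccc2c(=O)c(Cc3ccccc3)c(C)[nH]c2c1` share the same atoms joined differently; how the two cores differ is not broken down here. In a physicochemical assay for solubility, read by HPLC, at pH 7.4 (on this read-out higher numbers stand for higher solubility and lower numbers for lower solubility), compound 1 gives 2000 nM, and compound 2 gives 5000 nM. Compound 3 `COc1ccc2c(c1)c(=O)c(Cc1ccccc1)c(C)n2C` carries methyl in place of hydrogen on an aromatic nitrogen relative to compound 1, and in this assay compound 3 gives 10000 nM, so that a 5.0-fold higher number from compound 1 to compound 3 (0.70 log units; beyond the scatter). Compound 4 `COc1ccc2c(=O)c(Cc3ccccc3)c(C)n(C)c2c1` is not yet measured; it carries methyl in place of hydrogen on an aromatic nitrogen relative to compound 2, the same change as that from compound 1 to compound 3, made on the core of compound 2. Resting on compound 1 and compound 3, whose step is a 5.0-fold higher number from compound 1 to compound 3 (0.70 log units; beyond the scatter), compound 4 is expected to show a 4.0-fold higher number from compound 2 to compound 4 (0.60 log units; beyond the scatter) in this assay. The estimate for compound 4 is 20000 nM, between 8000 nM and 50000 nM.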

Compound 4, solubility: > 20000 nM
Compound 4: no number, only a limit (the forecaster's own chance of this, stated with the estimate: 5%); the middle value sits exactly at the limit.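

In this assay, methyl in place of hydrogen on an aromatic nitrogen moves the number the same way on both cores, with a 5.0-fold higher number from compound 1 to compound 3 (0.70 log units; beyond the scatter) and with an at least 4.0-fold higher number from compound 2 to compound 4 (0.60 log units; beyond the scatter) on the second core. Compound 4 gives > 20000 nM in this assay and that is a limit of the assay, not a number. The direction therefore carries over in this one pair of cores, but whether the step has the same size on both cannot be read: the limit of > 20000 nM in this assay, at which 1 of the 4 values shown sits.

The compounds shown carry only hydrogen or methyl on that nitrogen. As far as these compounds go, how an ethyl group, a longer chain ending in an amine, or a chain ending in a carboxylic acid would read there in this assay stays open on either core.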